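The source may report more compounds than this note shows. Statements on the series, on what has been measured and on what is new or still open speak of the compounds shown alone.

Measured compounds in a functional assay on T47D cells (Homo sapiens) for cytotoxicity, read by sulforhodamine B assay, with a stated time of 48 h; a higher number here means a weaker inhibitor, a lower number a stronger inhibitor:
compound 1 `NS(=O)(=O)c1ccc(N/C=C\C(=O)c2cc3ccccc3oc2=O)cc1`: 109000 nM
compound 2 `N=C(N)NS(=O)(=O)c1ccc(N/C=C\C(=O)c2cc3ccccc3oc2=O)cc1`: 87600 nM

Going by the values given here, compound 2 stands beside compound 1: the one measured step, a 1.2-fold lower number from compound 1 to compound 2 (0.09 log units; within the scatter), is within the scatter, so the two numbers cannot be told apart. Compound 3 `Cc1cc(NS(=O)(=O)c2ccc(N/C=C\C(=O)c3cc4ccccc4oc3=O)cc2)on1` differs from compound 2 by a group of 6 heavy atoms (4 carbon, 1 nitrogen, 1 oxygen; one five-membered aromatic ring with 2 hetero atoms) in place of a group of 3 heavy atoms (1 carbon, 2 nitrogen; no ring), on a sulfonamide nitrogen. Among the compounds with values here, the only step that bears on this is the one from compound 1 to compound 2, which also altered the sulfonamide nitrogen and left this assay essentially unchanged. Compound 3 is therefore expected to show a 1.1-fold lower number from compound 2 to compound 3 (0.04 log units; within the scatter), no step beyond the scatter. The estimate for compound 3 is 80000 nM, with a range of 30000 nM to 200000 nM.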

Compound 3, half-maximal inhibitory concentration: 75600 nM
For compound 3 the middle estimate is 1.1-fold (0.02 log units) above the measured one, within the range that was stated.
By their numbers in this assay, from the lowest: compounds 3, 2 and 1 (each within the scatter of the next).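

In this assay, 3-methyl-1,2-oxazol-5-yl on the sulfonamide nitrogen gives a 1.2-fold lower number from compound 2 to compound 3 (0.06 log units; within the scatter) when it replaces the earlier group, and a 1.4-fold lower number from compound 1 to compound 3 (0.16 log units; within the scatter) as well when it replaces hydrogen. So a five-membered aromatic ring at this position, not only the ringless group of compound 2, gives a number that cannot be told apart from those of compound 1 and compound 2. Nothing available explains this result. As far as these compounds go, whether an amine, a carboxylic acid or a longer chain on this nitrogen would behave alike remains open, and so does whether any group here can produce a step beyond the scatter.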